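From Methoxy to Cyclopentyloxy: An Estimate for Compound 4

A few compounds are considered here, and "the series" means these few. Any claim that something is new, unique, unknown or untested is made for them only; others in the source may bear on it.

Three compounds carry numbers in an ADME assay on NCM460 cells (Homo sapiens) for cytotoxicity, read by MTT assay, with a stated time of 72 h, in the presence of a further agent that is not named here; a lower number here means that less compound is needed, a higher number that more compound is needed for the effect. Compound 1 `O=C(Nc1cc(Cl)nc(Cl)c1)Nc1cc2ccc(-c3ccccc3)cn2n1` gives 8050 nM, and compound 2 `O=C(Nc1cc(Cl)nc(Cl)c1)Nc1cc(Cl)nc(Cl)c1` gives 9440 nM; these two lie within the scatter of one another. Compound 3 `COc1cc(NC(=O)Nc2cc(Cl)nc(Cl)c2)cc(Cl)n1` gives 33200 nM, the highest of the three, and the step of a 3.5-fold higher number from compound 2 to compound 3 (0.55 log units; beyond the scatter) lies beyond the scatter. Compound 4 `O=C(Nc1cc(Cl)nc(Cl)c1)Nc1cc(Cl)nc(OC2CCCC2)c1` differs from compound 3 by cyclopentyl in place of methyl on an oxygen on an aromatic ring. For the measured compounds named here, no measured step exchanges one alkyl for another on that oxygen; the only step touching this ring is the chloro-to-methoxy change, which was modest in size. For compound 4 the expected step is therefore a 1.2-fold higher number from compound 3 to compound 4 (0.08 log units; within the scatter), a small rise if any, giving an estimated 40000 nM with a range from 15000 nM to 100000 nM.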

Compound 4, half-maximal effective concentration: 21400 nM
Compound 4: middle estimate off by 1.9-fold (0.27 log units), on the high side; low and high end bracket the measured number.
By their numbers in this assay, from the lowest: compounds 1 and 2 (each within the scatter of the next); then compounds 4 and 3 (each within the scatter of the next).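

In this assay, for the compounds shown here, cyclopentyl in place of methyl on this oxygen gives the first exchange of one alkyl for another here, and the change stays within the scatter (a 1.6-fold lower number from compound 3 to compound 4 (0.19 log units; within the scatter)). The cyclopentyloxy group still differs from chloro on this aromatic carbon by more than the scatter (a 2.3-fold higher number from compound 2 to compound 4 (0.36 log units; beyond the scatter)), so both ether groups shown stand apart from chloro. No evidence bears on the cause of either step. The compounds shown leave open whether a longer chain on this oxygen would also stay within the scatter of compound 3. They also leave open how an amine in place of chloro on this aromatic carbon would compare.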